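The compounds below may be only part of what the source reports. "The series", "measured", "known", "first", "only" and "open" are said of these compounds alone.

Measured so far:
- Compound 1 `CCCn1c(=O)[nH]c2nc(-c3ccc(S(=O)(=O)N4CCN(c5ccccc5C)CC4)cc3)[nH]c2c1=O` — 0.432 nM
- Compound 2 `CCCn1c(=O)[nH]c2nc(-c3ccc(S(=O)(=O)N4CCN(C)CC4)cc3)[nH]c2c1=O` — 48.2 nM

In an assay on CHO cells for displacement of a labelled ligand from adenosine receptor A2b (Homo sapiens), read by scintillation counting, with a stated time of 75 min, in the presence of a further agent that is not named here (a lower number here means a stronger inhibitor, a higher number a weaker inhibitor), compound 2 gives 48.2 nM, the highest number of the two. For the measured compounds named here, the single measured step bearing on this series is a 110-fold higher number from compound 1 to compound 2 (2.05 log units; beyond the scatter), a large loss when an aryl group on the ring nitrogen is exchanged for methyl.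

Compound 3 `CCCn1c(=O)[nH]c2nc(-c3ccc(S(=O)(=O)N4CCN(c5cccc(Cl)c5)CC4)cc3)[nH]c2c1=O` is not yet measured. The change from compound 2 is 3-chlorophenyl in place of methyl on an amine nitrogen in a ring, i.e. an aryl group is restored on the same ring nitrogen, differing from compound 1 only in the substituent on that phenyl ring. Going by these compounds, because of a 110-fold higher number from compound 1 to compound 2 (2.05 log units; beyond the scatter), the expected direction is a strong lowering of the number in this assay, of a size comparable to that step reversed; whether a 3-chlorophenyl matches a 2-methylphenyl exactly is unknown, so the range is kept wide. The expected step is a 60-fold lower number from compound 2 to compound 3 (1.78 log units; beyond the scatter). Compound 3 is therefore estimated at 0.8 nM, within 0.2 nM to 4 nM.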

Compound 3, inhibition constant: 0.342 nM
Beside the measured number, compound 3's estimate is 2.3-fold (0.37 log units) above it; low and high end bracket the measured number.
By their numbers in this assay, from the lowest: compounds 3 and 1 (each within the scatter of the next); then compound 2.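

In this assay 3-chlorophenyl on this amine nitrogen gives a 140-fold lower number from compound 2 to compound 3 (2.15 log units; beyond the scatter) in place of methyl, so the large gain over methyl is no longer tied to 2-methylphenyl alone and holds for both aryl groups shown. Between the two aryl groups the comparison gives a 1.3-fold lower number from compound 1 to compound 3 (0.10 log units; within the scatter) and thus no separation, so this pair does not distinguish the methyl and chlorine substituents or their different places on the phenyl ring. Nothing at hand gives a reason for the gain over methyl or for the lack of separation between the aryl groups.

Open, going by these compounds, is where unsubstituted phenyl, benzyl or a longer alkyl chain such as butyl would fall on this nitrogen. Also open, on these data alone, is whether a pyridine ring would retain the gain seen with the two phenyl groups.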